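Bromo to amino on the chain of compound 1

A few compounds are considered here, and "the series" means these few. Any claim that something is new, unique, unknown or untested is made for them only; others in the source may bear on it.

In a functional assay on HeLa cells (Homo sapiens) for antiproliferative activity, read by MTT assay, with a stated time of 48 h (on this read-out lower numbers stand for stronger inhibition and higher numbers for weaker inhibition), compound 1 (`COc1ccc(C(=O)c2ccc(OC)c3c2C=CC(C)(C)O3)c(NC(=O)CBr)c1`) gives 3680 nM and compound 2 (`COc1ccc(C(=O)c2ccc3c(c2)C=CC(C)(C)O3)c(NC(=O)CBr)c1`) gives 3050 nM, two values within the scatter of each other. Compound 3 (`COc1ccc(C(=O)c2ccc(OC)c3c2OC(C)(C)C=C3)c(NC(=O)CO)c1`) gives 100 nM, lower than both beyond the scatter, so compound 1 stands level with compound 2 and well above compound 3. Compound 4 (`COc1ccc(C(=O)c2ccc(OC)c3c2C=CC(C)(C)O3)c(NC(=O)CN)c1`) keeps the core of compound 1, with amino in place of bromo on a saturated chain carbon bound to a carbonyl carbon. For the measured compounds named here, no measured pair isolates this change. The expectation leans on compound 3 at 100 nM, which also lacks bromo, although its core differs. A fall beyond the scatter is expected, a 12-fold lower number from compound 1 to compound 4 (1.09 log units; beyond the scatter). For compound 4 the estimated value is 300 nM, within a range of 50 nM to 1800 nM.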

Compound 4, half-maximal inhibitory concentration: 100 nM
Beside the measured number, compound 4's estimate is 3.0-fold (0.48 log units) above it; low and high end bracket the measured number.
By their numbers in this assay, from the lowest: compounds 3 and 4 (each within the scatter of the next); then compounds 2 and 1 (each within the scatter of the next).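

In this assay, for the compounds shown here, amino in place of bromo on a saturated chain carbon bound to a carbonyl carbon gives a 37-fold lower number from compound 1 to compound 4 (1.57 log units; beyond the scatter), the first change read in one place alone. This position therefore responds strongly to the group it carries, and bromo is not required for a low number on this core. No measurement at hand accounts for the size of this step. Open, on these data alone, is whether a methylamino or dimethylamino group, or a longer chain ending in an amine, holds the lower number.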